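The source may report more compounds than this note shows. Statements on the series, on what has been measured and on what is new or still open speak of the compounds shown alone.

Compound 1, `CNC(=O)c1cc(Oc2ccc(NC(=O)c3cc(-c4ccc(Br)cc4)ncn3)cc2)ccn1`, and compound 2, `CNC(=O)c1cc(Oc2ccc(NC(=O)c3cc(-c4ccc(Br)cc4)ncn3)cc2F)ccn1`, share one core, while compound 3, `CNC(=O)c1cc(Oc2ccc(NC(=O)c3nccc(-c4ccc(C)cc4)n3)cc2)ccn1`, and compound 4, `CNC(=O)c1cc(Oc2ccc(NC(=O)c3nccc(-c4ccc(C)cc4)n3)cc2F)ccn1`, share another; how the two cores differ is not broken down here. In a functional assay on PC-3 cells (Homo sapiens) for cytotoxicity, read by MTT assay, with a stated time of 72 h (on this read-out lower numbers stand for stronger inhibition and higher numbers for weaker inhibition), compound 1 gives > 100000 nM, which is a limit of the assay rather than a number. In this assay compound 2 likewise gives > 100000 nM, again a limit. The change between them, (fluoro in place of hydrogen on an aromatic carbon), therefore makes a step that the two limits leave unreadable from compound 1 to compound 2, unreadable because of the limit of > 100000 nM in this assay, at which 2 of the 3 values shown sit. In this assay, among the compounds with values here, compound 3 gives 13100 nM, the only number among the three. Compound 4 carries the same change on its own core, (fluoro in place of hydrogen on an aromatic carbon). With no readable size for the earlier step, the step from compound 3 to compound 4 is expected to be small, about a 1.1-fold higher number from compound 3 to compound 4 (0.03 log units; within the scatter). Compound 4 is accordingly estimated at 14000 nM, most likely between 5000 nM and 45000 nM.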

Compound 4, half-maximal inhibitory concentration: 28400 nM
Beside the measured number, compound 4's estimate is 2.0-fold (0.31 log units) below it; measured number inside the range.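

In this assay, fluoro in place of hydrogen on an aromatic carbon makes a 2.2-fold higher number from compound 3 to compound 4 (0.34 log units; beyond the scatter), a modest move towards weaker inhibition on the core of compound 3. The same change on the core of compound 1 cannot be read, so the data do not show whether the step carries from one core to the other, because both values there are limits of the assay: the limit of > 100000 nM in this assay, at which 2 of the 4 values shown sit. The series therefore offers one readable step on one core, which neither confirms nor rules out transfer.

The compounds shown leave open whether chloro, methoxy or an amine on that aromatic carbon would move the number as fluoro does. They also leave open what a longer chain in place of the methyl of the methylcarbamoyl group would do on either core.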